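Working notes: chain swap at the shared core

This account rests on a few compounds, and the source may have more. Where it says the series, first, only, none or still open, it means among the compounds named here.

Measured so far in an ADME assay on HepG2 cells (Homo sapiens) for cytotoxicity, read by luminescence, CellTiter-Glo and ATP content, with a stated time of 72 h; a lower number here means that less compound is needed, a higher number that more compound is needed for the effect:
compound 1 `COc1ccc(F)cc1CNCCCNc1ccnc2cc(CCc3ccccc3)ccc12` gives 4240 nM
compound 2 `COc1ccc(F)cc1CNCCCNc1ccnc2cc(-c3ccc(F)cc3)ccc12` gives 770 nM
compound 3 `COc1ccc(F)cc1CNCCCNc1ccnc2cc(-c3ccccc3)ccc12` gives 2960 nM

Compound 3 stands second highest of the three. Compound 1 is nearest, within the scatter, as a 1.4-fold lower number from compound 1 to compound 3 (0.16 log units; within the scatter) shows, and compound 2 furthest, as a 3.8-fold higher number from compound 2 to compound 3 (0.58 log units; beyond the scatter) shows. The next compound, compound 4 `CCC(CC)c1ccc2c(NCCCNCc3cc(F)ccc3OC)ccnc2c1`, differs from compound 3 by pentan-3-yl in place of phenyl on an aromatic carbon. Among the compounds with values here, no measured step replaces an aromatic ring with a branched chain at this position. The closest guide is a 1.4-fold lower number from compound 1 to compound 3 (0.16 log units; within the scatter), which left the number within the scatter, while a 5.5-fold lower number from compound 1 to compound 2 (0.74 log units; beyond the scatter) shows that this position can move the number. Without a direct precedent, no step beyond the scatter is expected, so the step of a 1.0-fold higher number from compound 3 to compound 4 (0.01 log units; within the scatter) is the estimate. Compound 4 is therefore expected near 3000 nM, between 1200 nM and 8000 nM.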

Compound 4, half-maximal effective concentration: 7860 nM
Beside the measured number, compound 4's estimate is 2.6-fold (0.42 log units) below it, within the range that was stated.
By their numbers in this assay, from the lowest: compound 2; then compounds 3, 1 and 4 (each within the scatter of the next, the first and the last beyond it).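

In this assay, within the data shown here, this position also responds to losing the ring: pentan-3-yl, with no ring, gives a 2.7-fold higher number from compound 3 to compound 4 (0.42 log units; beyond the scatter) and a 10-fold higher number from compound 2 to compound 4 (1.01 log units; beyond the scatter), the latter the largest step so far. The change from phenethyl stays within the scatter, at a 1.9-fold higher number from compound 1 to compound 4 (0.27 log units; within the scatter), so a ring-free branched chain and phenethyl cannot be told apart here. No evidence on the origin of these steps is available.

On these data alone, it remains open whether cyclohexyl, a saturated ring, would track pentan-3-yl or phenyl. The effect of an amine or a carboxylic acid at this position is also unknown.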